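The source may report more compounds than this note shows. Statements on the series, on what has been measured and on what is new or still open speak of the compounds shown alone.

Compound 1, `OC[C@H]1O[C@@H](n2cnc3c(O)ncnc32)CS1`, in a functional assay on Vero cells (Chlorocebus sabaeus) for inhibition; on this read-out higher numbers stand for weaker inhibition and lower numbers for stronger inhibition: > 100000 nM, a limit of the assay.
Compound 2, `O=c1[nH]c(=O)n([C@@H]2CS[C@@H](CO)O2)cc1Br`, in this assay: > 100000 nM, a limit of the assay.
Compound 3, `Nc1ncnc2c1ncn2[C@@H]1CS[C@@H](CO)O1`, in this assay: > 100000 nM, a limit of the assay.

Compound 2 stands where every measured compound stands, at the limit of > 100000 nM in this assay, at which 3 of the 3 values shown sit. Going by the values given here, none of the three results is a number, so no step between measured compounds can be given, and nothing among them separates one from another. Compound 4, `O=c1[nH]c(=O)n([C@@H]2CS[C@@H](CO)O2)cc1I`, differs from compound 2 in a single place: iodo in place of bromo on an aromatic carbon. Among the compounds with values here, with no measured step to lean on, the expected change a number no higher from compound 2 to compound 4 (the limit leaves the size open) is none beyond the scatter; the one exchange of a halogen on the aromatic carbon gives no ground to expect compound 4 to move off the limit where compound 2 sits. Compound 4 is therefore estimated at 100000 nM, within 30000 nM to 300000 nM, and it is most likely that the assay again reports only its limit for compound 4 rather than a number.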

Compound 4, half-maximal inhibitory concentration: > 100000 nM
Compound 4 gave a limit, no number; the forecaster's own chance of this, stated with the estimate: 80%; the middle value sits exactly at the limit.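

In this assay, going by these compounds alone, compound 2 and compound 4 both gave only a limit, so the exchange of bromo for iodo yields no step that can be read. The compounds shown leave open how strongly any of them inhibits, as all share one limit: the limit of > 100000 nM in this assay, at which 4 of the 4 values shown sit.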